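Does a Longer Chain Still Raise Growth Inhibition?

This account rests on a few compounds, and the source may have more. Where it says the series, first, only, none or still open, it means among the compounds named here.

Three measured compounds share one core and differ only in the saturated chain on a carbonyl carbon: compound 1 (`C=C[C@@](C)(/C=C/c1ccc(OC(=O)CCC)cc1)CCC=C(C)C`), compound 2 (`C=C[C@@](C)(/C=C/c1ccc(OC(=O)CCCCC)cc1)CCC=C(C)C`) and compound 3 (`C=C[C@@](C)(/C=C/c1ccc(OC(=O)CCCCCCC)cc1)CCC=C(C)C`). In a functional assay on HeLa cells (Homo sapiens) for inhibition, with a stated time of 48 h, tested at 50 uM (a higher number here means more inhibition of growth at the concentration tested, a lower number less inhibition of growth), compound 1 gives 36%, compound 2 gives 50% and compound 3 gives 53%. Compound 3 therefore stands level with compound 2 and clear of compound 1.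

Compound 4 (`C=C[C@@](C)(/C=C/c1ccc(OC(=O)CCCCCCCCC)cc1)CCC=C(C)C`) takes the same kind of change one stage further, with ethyl in place of hydrogen on a saturated chain carbon, seven bonds along the chain from a carbonyl carbon. For the measured compounds named here, three measured steps bear on this. The first, a number 14 percentage points higher from compound 1 to compound 2 (beyond the scatter), lies beyond the scatter, as does the combined step, a number 17 percentage points higher from compound 1 to compound 3 (beyond the scatter). The most recent, a number 3 percentage points higher from compound 2 to compound 3 (within the scatter), stays within it. Among these compounds, then, the clear difference appears only early in the chain, and no measurement yet shows what a still longer chain does. The most recent step is the closest guide, so no step beyond the scatter is expected in this assay. The estimated step is a number 3 percentage points lower from compound 3 to compound 4 (within the scatter). Compound 4 is expected at 50%, with an estimated range from 37% to 63%.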

Compound 4, percent growth inhibition at one concentration: 50%
Compound 4: the middle estimate sits on the measured number at the digits printed, within the range that was stated.
By their numbers in this assay, from the lowest: compound 1; then compounds 2, 4 and 3 (each within the scatter of the next).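

The chain has now been extended past the point where the earlier gain stopped. In this assay, ethyl in place of hydrogen on a saturated chain carbon, seven bonds along the chain from a carbonyl carbon, gives a number 3 percentage points lower from compound 3 to compound 4 (within the scatter), and the longer comparison gives no change at the digits printed from compound 2 to compound 4 (within the scatter), so neither extension beyond the shorter chains produces a clear step. A clear step remains only when the comparison starts from the shortest chain, a number 14 percentage points higher from compound 1 to compound 4 (beyond the scatter), so the early difference persists at this chain length and no further clear difference appears. The same ethyl change therefore depends on where it is made along the chain, a difference larger than the scatter alone would give: the same change on two cores in this assay, a number 14 percentage points higher (beyond the scatter) from compound 1 to compound 2 and a number 3 percentage points lower (within the scatter) from compound 3 to compound 4, 17 percentage points apart, beyond the scatter of two such steps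

These compounds leave open whether a still longer chain, or a chain ending in an amine or a carboxylic acid, would shift growth inhibition beyond the scatter. With only one tested concentration shown, they also leave open how the compounds would compare at other concentrations.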